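Dropping the fluoro from the phenoxy group of compound 2

A few compounds are considered here, and "the series" means these few. Any claim that something is new, unique, unknown or untested is made for them only; others in the source may bear on it.

Measured compounds:
compound 1, `COc1cc(C(C)=O)ccc1OCCCN1CCC(C(c2ccc(F)cc2)C2CCCCC2)CC1`, 5.01 nM
compound 2, `Fc1ccc(OCCCN2CCC(C(c3ccc(F)cc3)c3ccc(F)cc3)CC2)cc1`, 1.26 nM

Both compounds were examined in a functional assay (aorta) with Oryctolagus cuniculus as the target; a lower number here means tighter binding, a higher number weaker binding. Compound 1 gives 5.01 nM in this assay, and compound 2 gives 1.26 nM. Compound 2 thus holds the lowest number of the two, and the gap to compound 1 lies beyond the scatter of the method.

Compound 3, `Fc1ccc(C(c2ccc(F)cc2)C2CCN(CCCOc3ccccc3)CC2)cc1`, has not yet been measured in this assay. It differs from compound 2 in one place: hydrogen in place of fluoro on an aromatic carbon. No change of this kind has been measured between any two compounds here, so the size of the step can only be anticipated.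

With hydrogen in place of fluoro on an aromatic carbon, the change is small in what is counted, and the step from compound 2 is expected to be modest, a 1.6-fold higher number from compound 2 to compound 3 (0.20 log units; within the scatter), most likely within the usual scatter. For compound 3 the dissociation constant in this assay is therefore estimated at 2 nM, with a range from 0.6 nM to 6.3 nM.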

Compound 3, dissociation constant: 1.59 nM
The estimate for compound 3 lay 1.3-fold (0.10 log units) above the measured number; measured number inside the range.
By their numbers in this assay, from the lowest: compounds 2 and 3 (each within the scatter of the next); then compound 1.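

In this assay, replacing 4-fluorophenoxy with phenoxy gives a 1.3-fold higher number from compound 2 to compound 3 (0.10 log units; within the scatter) and so leaves compound 2 and compound 3 indistinguishable. Among the compounds shown here, this is the first step between compounds that differ in one place, and it shows that the fluoro on this ring, para to a large group, is not required for a number at the level of compound 2. No measurement in hand explains this result.

On these data alone, it remains open whether a chloro, a methoxy or a nitrile in the same place would also leave the number at this level. Also open, as far as these compounds go, is whether hydrogen could replace fluoro on the two 4-fluorophenyl groups of the core with as small a step.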